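The source may report more compounds than this note shows. Statements on the series, on what has been measured and on what is new or still open speak of the compounds shown alone.

Working notes on the series. Compound 1 `CCOC(=O)C1=C(C)N/C(=C/c2cc(C)n(-c3ccc(Br)cc3)c2C)C1=O` is the reference point. Among the compounds with values here, in an ADME assay on L6 cells (Rattus norvegicus) for cytotoxicity, read by resazurin assay, with a stated time of 72 h (a higher number here means that more compound is needed for the effect, a lower number that less compound is needed), compound 1 gives 100000 nM, the highest of the two numbers measured so far; its nearest neighbour is compound 2 `CCOC(=O)C1=C(C)N/C(=C/c2cc(C)n(-c3cccc(O)c3)c2C)C1=O`, which in this assay gives 69000 nM. Within the data shown here, the one step in hand, a 1.4-fold lower number from compound 1 to compound 2 (0.16 log units; within the scatter), exchanges the aryl on the aromatic nitrogen and stays within the scatter.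

Compound 3 `CCOC(=O)C1=C(C)N/C(=C/c2cc(C)n(-c3ccc(SC)cc3)c2C)C1=O` is not yet measured. It differs from compound 1 as methylsulfanyl in place of bromo on an aromatic carbon. Among the measured compounds shown here, no measured step touches this position on the aryl ring; the only step that alters that ring at all is a 1.4-fold lower number from compound 1 to compound 2 (0.16 log units; within the scatter), and it is within the scatter. On that basis no step beyond the scatter is expected for compound 3, and the step of a 1.1-fold lower number from compound 1 to compound 3 (0.05 log units; within the scatter) is taken as essentially flat. Compound 3 is therefore estimated at 90000 nM in this assay, with a range of 40000 nM to 200000 nM.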

Compound 3, half-maximal effective concentration: 54000 nM
Beside the measured number, compound 3's estimate is 1.7-fold (0.22 log units) above it, within the range that was stated.
By their numbers in this assay, from the lowest: compounds 3, 2 and 1 (each within the scatter of the next).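

In this assay, within the data shown here, methylsulfanyl in place of bromo on the aromatic carbon para to a large group gives a 1.9-fold lower number from compound 1 to compound 3 (0.27 log units; within the scatter) and so stays within the scatter, the first reading of a change at this position. The exchange of 3-hydroxyphenyl for 4-(methylsulfanyl)phenyl on the aromatic nitrogen gives a 1.3-fold lower number from compound 2 to compound 3 (0.11 log units; within the scatter) and also stays within the scatter, so neither change separates compound 3 from its two neighbours in this assay. No measured property bears on these steps.

On these data alone, whether an amine, a carboxylic acid or a longer chain on this aromatic carbon would give a step beyond the scatter remains open. As far as these compounds go, all three compounds share the core of compound 1, so the effect of changes elsewhere on that core also remains open.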